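A group swap on a carbonyl carbon

The source may report more compounds than this note shows. Statements on the series, on what has been measured and on what is new or still open speak of the compounds shown alone.

Measured in an ADME assay on microsomes from liver (Rattus norvegicus) for metabolic stability, read by LC-MS, using NADPH, at 37 degrees C; a higher number here means that the compound lasts longer, a lower number that the compound disappears faster:
Compound 1 `Cc1ccccc1-c1nc(CN2CCC(C(=O)NCCCN3CCC(C)(C)CC3)CC2)c(C)o1`: > 0.5 h (a limit)
Compound 2 `Cc1ccccc1-c1nc(CN2CCC(C(=O)NCCN3C[C@H](C)C[C@H](C)C3)CC2)c(C)o1`: > 0.5 h (a limit)

Neither entry is a true number. Compound 2 has only a limit, > 0.5 h, and it offers no exact half-life to start from. The same holds across the whole small set: the limit of > 0.5 h in this assay, at which 2 of the 2 values shown sit.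

Compound 3 `Cc1ccccc1-c1nc(CN2CCC(C(=O)N3CCN(CCN(C)C)CC3)CC2)c(C)o1` changes the group on the carbonyl carbon, bringing in 4-(2-(dimethylamino)ethyl)piperazin-1-yl: a group of 11 heavy atoms (8 carbon, 3 nitrogen; one six-membered non-aromatic ring with 2 hetero atoms) in place of a group of 11 heavy atoms (9 carbon, 2 nitrogen; one six-membered non-aromatic ring with 1 hetero atom), on a carbonyl carbon. The core stays the same.

Going by the values given here, the only measured step is a step that the two limits leave unreadable from compound 1 to compound 2. It took place at a different part of the side chain, and it has no readable size to carry over. The data therefore give no reason to expect a step beyond the scatter in this assay, and no direction can be assigned. The expected change is a number no higher from compound 2 to compound 3 (the limit leaves the size open), an estimate that rests on very little evidence. For compound 3 the estimated half-life is 0.5 h, with an expected range from 0.2 h to 1 h.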

Compound 3, half-life: > 0.5 h
Compound 3: only a limit was reported; the forecaster's own chance of this, stated with the estimate: 60%; the middle value sits exactly at the limit.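

In this assay compound 3 gives > 0.5 h, which is a limit and not a number. Compound 2 also has only a limit, so no step can be read from compound 2 to compound 3. The compounds shown leave open the true half-lives and whether the group swap on the carbonyl carbon changes them at all: the limit of > 0.5 h in this assay, at which 3 of the 3 values shown sit.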